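The source may report more compounds than this note shows. Statements on the series, on what has been measured and on what is new or still open speak of the compounds shown alone.

Compound 1 `COc1ccc(CN(C(=O)CSc2nc3ccccc3s2)c2cc(OC)c(OC)c(OC)c2)cc1`: 163 nM
Compound 2 `COc1cc(CN(C(=O)CSc2nc3ccccc3s2)c2cc(OC)c(OC)c(OC)c2)cc(OC)c1OC`: 45700 nM
Compound 3 `COc1ccc2nc(SCC(=O)N(Cc3ccc(OC)c(O)c3)c3cc(OC)c(OC)c(OC)c3)sc2c1`: 71 nM

All three values come from a functional assay on MGC-803 cells (Homo sapiens) for antiproliferative activity, read by MTT assay, with a stated time of 48 h; a higher number here means a weaker inhibitor, a lower number a stronger inhibitor. Compound 2, at 45700 nM, has the highest number of the three and is the weakest inhibitor in the set. The next compound, compound 4 `COc1ccc(CN(C(=O)CSc2nc3ccccc3s2)c2cc(OC)c(OC)c(OC)c2)cc1F`, has not yet been measured. Its change from compound 2 is 3-fluoro-4-methoxyphenyl in place of 3,4,5-trimethoxyphenyl on a saturated chain carbon bound to an amide-type nitrogen.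

Among the measured compounds shown here, one measured step bears directly on this change. Placing 3,4,5-trimethoxyphenyl where compound 1 carries 4-methoxyphenyl gave a 280-fold higher number from compound 1 to compound 2 (2.45 log units; beyond the scatter). Compound 4 leaves the 3,4,5-trimethoxyphenyl group and returns to a group that keeps the 4-methoxy pattern, now as 3-fluoro-4-methoxyphenyl, so most of that large step should be reversed. Compound 3 also lacks the 3,4,5-trimethoxyphenyl group and gives 71 nM, although it differs from compound 1 in more than one place. For the measured compounds named here, no measured compound here carries fluorine, so the effect of that atom remains open and the range must stay wide.

A large fall in the number is therefore expected in this assay, and the estimated change is a 230-fold lower number from compound 2 to compound 4 (2.36 log units; beyond the scatter). For compound 4 the estimated value is 200 nM, with an expected range from 60 nM to 900 nM.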

Compound 4, half-maximal inhibitory concentration: 416 nM
The estimate for compound 4 lay 2.1-fold (0.32 log units) below the measured number, and the stated range covers the measured number.
By their numbers in this assay, from the lowest: compound 3; then compound 1; then compound 4; then compound 2.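

In this assay, 3-fluoro-4-methoxyphenyl in place of 3,4,5-trimethoxyphenyl on a saturated chain carbon bound to an amide-type nitrogen gave a 110-fold lower number from compound 2 to compound 4 (2.04 log units; beyond the scatter) and thus showed that the large loss seen with compound 2 does not follow from every added substituent on this ring. Fluoro in place of hydrogen on an aromatic carbon gave a 2.6-fold higher number from compound 1 to compound 4 (0.41 log units; beyond the scatter) as a modest step, so this atom, the first fluorine in the series, recovers nearly all of the ground lost with compound 2 but does not improve on compound 1 in this assay. The compounds shown come with no measurement that would explain either step.

On these data alone, what remains open is whether the modest loss belongs to fluorine itself or would also appear with another small group in its place, such as a chlorine atom, a methyl group or a nitrile. The low number of compound 3 also stays unassigned, since it differs from the other compounds in more than one place and no single change can be credited with its value.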